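This account rests on a few compounds, and the source may have more. Where it says the series, first, only, none or still open, it means among the compounds named here.

Compound 1 `CC#CC(CC(=O)O)c1ccc(OCc2ccc3nc(-c4ccc(CC)cc4)cn3c2)cc1` gives 496 nM in an assay on isolated protein for agonist activity at Free fatty acid receptor 1 (Homo sapiens); on this read-out higher numbers stand for an effect only at larger amounts of compound and lower numbers for an effect already at smaller amounts.
Compound 2 `CC#CC(CC(=O)O)c1ccc(OCc2ccc3nc(-c4ccc(F)cc4F)cn3c2)cc1` gives 825 nM in this assay.
Compound 3 `CC#CC(CC(=O)O)c1ccc(OCc2ccc3nc(-c4ccc(F)cc4)cn3c2)cc1` gives 623 nM in this assay.

Compound 3 stands second highest of the three numbers, with compound 1 nearest and compound 2 furthest; all three lie within the scatter of one another, so no order among them can be read. The step to compound 4 `CC#CC(CC(=O)O)c1ccc(OCc2ccc3nc(-c4ccc(C5CCCCC5)cc4)cn3c2)cc1` is cyclohexyl in place of fluoro on an aromatic carbon. The measured steps that bear on this change are the two that touch the same group: a 1.3-fold higher number from compound 1 to compound 3 (0.10 log units; within the scatter), where the other group on that carbon was ethyl, and a 1.3-fold lower number from compound 2 to compound 3 (0.12 log units; within the scatter), where only an extra fluoro elsewhere on the same ring was removed. Both were within the scatter, so the numbers give no sign that this position of the shared core moves the read-out much, but none of them carries a group as large as cyclohexyl, so the size of this step is not covered by any measured pair. The expectation is therefore a step of a 1.2-fold lower number from compound 3 to compound 4 (0.10 log units; within the scatter), that is, none beyond the scatter, with a wide range to allow for the untested size of the new group. Compound 4 is estimated at 500 nM, between 150 nM and 1700 nM.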

Compound 4, half-maximal effective concentration: 417 nM
Beside the measured number, compound 4's estimate is 1.2-fold (0.08 log units) above it; the measured number falls inside the stated range.
By their numbers in this assay, from the lowest: compounds 4, 1, 3 and 2 (each within the scatter of the next).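

In this assay, replacing the single fluorine with cyclohexyl, six carbon atoms in a non-aromatic ring, gives a 1.5-fold lower number from compound 3 to compound 4 (0.17 log units; within the scatter) and the other two routes to compound 4 read alike: cyclohexyl in place of ethyl gives a 1.2-fold lower number from compound 1 to compound 4 (0.08 log units; within the scatter) and 4-cyclohexylphenyl in place of 2,4-difluorophenyl gives a 2.0-fold lower number from compound 2 to compound 4 (0.30 log units; within the scatter). The earlier compounds shown here carried only fluoro or ethyl here, whereas these steps show that a group as large as cyclohexyl, on an aromatic carbon para to a large group, also brings no step beyond the scatter, so fluoro, ethyl and cyclohexyl cannot be told apart at this position. Nothing at hand offers an explanation for why the read-out stays within the scatter across these groups.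

Going by these compounds, whether an amine, a hydroxyl or a carboxylic acid on this aromatic carbon, or a longer chain such as octyl, would move the number beyond the scatter remains open. Also open, on these data alone, is whether a change elsewhere on the shared core, such as replacing its carboxylic acid with an amide, would matter more than any change at this position.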